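The source may report more compounds than this note shows. Statements on the series, on what has been measured and on what is new or still open speak of the compounds shown alone.

Measured so far in an assay on isolated protein for inhibition of aldehyde dehydrogenase 1A1 (Homo sapiens), read by spectrophotometry, tested at 10 uM; on this read-out lower numbers stand for less inhibition and higher numbers for more inhibition at the one concentration tested (going by the name of the read-out):
compound 1, `CC(C)CCn1c(CN2CCN(C(=O)c3ccco3)CC2)nc2ccccc21`, gives 42.1%
compound 2, `Cc1cccc(Cn2c(CN3CCN(C(=O)c4ccncc4)CC3)nc3ccccc32)c1`, gives 20.6%
compound 3, `CCC(=O)N1CCN(Cc2nc3ccccc3n2Cc2cccc(C)c2)CC1`, gives 85.1%

Compound 3 stands highest of the three numbers; its gap to compound 1 and its gap to compound 2 are both beyond the scatter, so on these numbers its inhibition in this assay is the highest of the measured set.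

Compound 4, `Cc1cccc(Cn2c(CN3CCN(C(=O)c4ccco4)CC3)nc3ccccc32)c1`, differs from compound 3 in one place: furan-2-yl in place of ethyl on a carbonyl carbon.

For the measured compounds named here, one measured step bears on this change, the one on the same carbonyl carbon: a number 64.5 percentage points higher from compound 2 to compound 3 (beyond the scatter). There the ring on the carbonyl gave way to ethyl and the number rose by a large amount. Compound 4 reverses the direction of that kind of change, putting a ring, furan-2-yl, back in place of ethyl. Going by the values given here, compound 1 also carries a (furan-2-yl)carbonyl, though on a core with a different group on the ring nitrogen, and gives a number well under that of compound 3; no step between compound 1 and compound 4 is computed here, so only the two values themselves are compared.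

A fall beyond the scatter is therefore expected for compound 4, a number 45.1 percentage points lower from compound 3 to compound 4 (beyond the scatter), landing near the value of compound 1. The estimate for compound 4 in this assay is 40%, with a range from 20% to 62%.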

Compound 4, a percentage reported as inhibition, at one concentration (the size of the read-out at that concentration, not a potency): 73.2%
Compound 4: the middle estimate sits 33.2 percentage points below what was measured, outside the stated range (above it).
By their numbers in this assay, from the lowest: compound 2; then compound 1; then compound 4; then compound 3.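

In this assay a ring on the carbonyl carbon is not in itself what costs most of the inhibition: furan-2-yl in place of ethyl gives a number 11.9 percentage points lower from compound 3 to compound 4 (beyond the scatter) and leaves only a modest loss. Furan-2-yl in place of pyridin-4-yl gives a number 52.6 percentage points higher from compound 2 to compound 4 (beyond the scatter) and so separates the two rings, which places the large loss on pyridin-4-yl specifically, though this rests on compound 2 alone. With the (furan-2-yl)carbonyl held constant, the group on the other side of the molecule also carries much of the read-out: 3-methylphenyl in place of isobutyl on a saturated chain carbon bound to an aromatic nitrogen gives a number 31.1 percentage points higher from compound 1 to compound 4 (beyond the scatter) and shows that the lower number of compound 1 comes from that change and not from the furan-2-yl.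

Open, going by these compounds, is whether a saturated ring such as cyclohexyl or a longer chain such as butyl on the carbonyl carbon would track ethyl or furan-2-yl, and whether the gain with 3-methylphenyl holds when propanoyl replaces the (furan-2-yl)carbonyl. No independent evidence is available to explain any of these steps.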